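The source may report more compounds than this note shows. Statements on the series, on what has been measured and on what is new or still open speak of the compounds shown alone.

Measured in an ADME assay on HEK293 cells (Homo sapiens) for cytotoxicity, read by MTT assay, with a stated time of 72 h (a lower number here means a stronger inhibitor, a higher number a weaker inhibitor), so far:
compound 1 `COc1ccc(C(=O)N2CCN(CC(=O)N3CCN(CCCc4c[nH]c5ccccc45)CC3)CC2)cc1` gives 156000 nM
compound 2 `Cc1ccc(C(=O)N2CCN(CC(=O)N3CCN(CCCc4c[nH]c5ccccc45)CC3)CC2)cc1` gives 159000 nM
compound 3 `O=C(CN1CCN(C(=O)c2cccc(Cl)c2)CC1)N1CCN(CCCc2c[nH]c3ccccc23)CC1` gives 99100 nM

Compound 1 stands in one band with compound 2 and compound 3, and nothing beyond the scatter separates the three. The exchange of methoxy for methyl is a very small step (a 1.0-fold higher number from compound 1 to compound 2 (0.01 log units; within the scatter)). The two exchanges for 3-chlorophenyl are also modest (a 1.6-fold lower number from compound 1 to compound 3 (0.20 log units; within the scatter)) and (a 1.6-fold lower number from compound 2 to compound 3 (0.21 log units; within the scatter)).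

Compound 4 `COc1ccc(C(=O)N2CCN(CC(=O)N3CCN(CCCc4c[nH]c5ccc(F)cc45)CC3)CC2)cc1` keeps the rest of compound 1 and has fluoro in place of hydrogen on an aromatic carbon, which turns 1H-indol-3-yl into 5-fluoro-1H-indol-3-yl (fluoro in place of hydrogen on an aromatic carbon). Among the compounds with values here, none of the measured steps touches this part of the structure, since all three alter the aromatic group on the carbonyl carbon. They bear on the new change only indirectly, and the data hold no direct measure of it. No step beyond the scatter is therefore expected in this assay. Within the data shown here, a slight lean to a lower number rests only on compound 3 (99100 nM), the one measured compound that carries a halogen. The expected change is small (a 1.2-fold lower number from compound 1 to compound 4 (0.08 log units; within the scatter)) and stays within the scatter. Compound 4 is estimated at 130000 nM, with an expected range of 70000 nM to 230000 nM.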

Compound 4, half-maximal inhibitory concentration: 141000 nM
Beside the measured number, compound 4's estimate is 1.1-fold (0.04 log units) below it; low and high end bracket the measured number.
By their numbers in this assay, from the lowest: compounds 3, 4, 1 and 2 (each within the scatter of the next).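

In this assay, within the data shown here, the exchange of 1H-indol-3-yl for 5-fluoro-1H-indol-3-yl gives a 1.1-fold lower number from compound 1 to compound 4 (0.04 log units; within the scatter), the first direct reading at this end of the molecule, since all the earlier steps altered only the aromatic group on the carbonyl carbon. It shows that a single fluoro in place of hydrogen on this aromatic carbon, para to a fused ring and meta to a fused ring, does not shift the number beyond the scatter when 4-methoxyphenyl stays on the carbonyl carbon. No measurement at hand explains this result.

As far as these compounds go, it remains open whether the same exchange would also stay within the scatter with 4-methylphenyl or 3-chlorophenyl on the carbonyl carbon, as in compound 2 and compound 3, because the fluoro has been read against only one partner here. The compounds shown also leave open how a carboxylic acid or an amine on the same aromatic carbon would read in this assay, as fluoro is the only group other than hydrogen shown at this place.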